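The compounds below may be only part of what the source reports. "The series", "measured", "known", "first", "only" and "open" are said of these compounds alone.

Values in a physicochemical assay for lipophilicity, at pH 7.4; on this read-out lower numbers stand for lower lipophilicity and higher numbers for higher lipophilicity:
- Compound 1 `COc1nnc2ccc(N3CCC(c4ccc(N5CCC(N6CCN(C)C(=O)[C@H]6C)CC5)cc4)CC3)nn12`: 2
- Compound 2 `COc1nnc2ccc(N3CCC(c4ccc(OCCCCN5CCN(C)C(=O)[C@H]5C)cc4)CC3)nn12`: 2.8
- Compound 3 `COc1nnc2ccc(N3CCC(c4ccc(N5CC(N6CCN(C)C(=O)[C@H]6C)C5)cc4)CC3)nn12`: 1.7

Compound 2 stands highest of these three, beyond the usual scatter above both compound 1 and compound 3. Compound 4 `COc1nnc2ccc(N3CCC(c4ccc(OCCCN5CCN(C)C(=O)[C@H]5C)cc4)CC3)nn12` has not yet been measured. It differs from compound 2 in one place: a group of 9 heavy atoms (6 carbon, 2 nitrogen, 1 oxygen; one six-membered non-aromatic ring with 2 hetero atoms) in place of a group of 10 heavy atoms (7 carbon, 2 nitrogen, 1 oxygen; one six-membered non-aromatic ring with 2 hetero atoms), on a saturated chain carbon, three bonds along the chain from an oxygen on an aromatic ring. For the measured compounds named here, no two measured compounds differ by a change of this kind, so the expectation rests on the structures alone. A small downward step in this assay is expected, close to the edge of the usual scatter. The expected change is a number 0.30 log units lower from compound 2 to compound 4 (within the scatter). The estimated value for compound 4 is 2.5, with an expected range of 2.1 to 2.8.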

Compound 4, distribution coefficient: 2.4
Compound 4: the middle estimate sits 0.10 log units above what was measured, within the range that was stated.
By their numbers in this assay, from the lowest: compounds 3 and 1 (each within the scatter of the next); then compound 4; then compound 2.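

In this assay, the group of 9 heavy atoms in place of the group of 10 heavy atoms, on a saturated chain carbon, three bonds along the chain from an oxygen on an aromatic ring, gives a number 0.40 log units lower from compound 2 to compound 4 (beyond the scatter). For the compounds shown here, this is the first comparison here between compounds that differ in only one place, and it shows that this small change in the chain can move the read-out beyond the usual scatter. No measurement here explains the step.

Going by these compounds, a single step establishes no trend, so it remains open whether a still shorter chain or a longer chain would continue in the same direction. On these data alone, the outcome of placing a hydroxyl group on this chain also remains open.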